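This account rests on a few compounds, and the source may have more. Where it says the series, first, only, none or still open, it means among the compounds named here.

Among the compounds with values here, compound 2, `CC1CCN(c2c(S(=O)(=O)c3ccc(Cl)cc3)cnc3cc(Cl)ccc23)CC1`, is one of two compounds measured in an assay on isolated protein for displacement of a labelled ligand from metabotropic glutamate receptor 5 (Homo sapiens), with a stated time of 60 min, tested at 1 uM; a lower number here means less inhibition, a higher number more inhibition at the concentration tested (going by the name of the read-out); in this assay compound 2 gives 91%. Within the data shown here, its only neighbour is compound 1, `CC1CCN(c2c(S(=O)(=O)c3cc(F)cc(F)c3)cnc3cc(Cl)ccc23)CC1`, which in this assay gives 94%. Among the measured compounds shown here, the single measured step, a number 3 percentage points lower from compound 1 to compound 2 (within the scatter), involves the same position that is varied below, and it lies within the scatter, so the two measured numbers cannot be told apart, even though the number of compound 2 is the one written lower of the two.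

Compound 3 is `COc1cccc(S(=O)(=O)c2cnc3cc(Cl)ccc3c2N2CCC(C)CC2)c1`. The change from compound 2 is 3-methoxyphenyl in place of 4-chlorophenyl on a sulfonyl sulfur. For the measured compounds named here, the one step that bears on this change is the exchange of one aryl group for another on the sulfonyl sulfur from compound 1 to compound 2, and that step was within the scatter. On that basis no step beyond the scatter is expected in this assay, in either direction, for the move to compound 3; the expected step is a number 3 percentage points lower from compound 2 to compound 3 (within the scatter). Compound 3 is therefore estimated to give 88% in this assay, with a range from 72% to 97%.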

Compound 3, a percentage reported as inhibition, at one concentration (the size of the read-out at that concentration, not a potency): 93%
The estimate for compound 3 lay 5 percentage points below the measured number; low and high end bracket the measured number.
By their numbers in this assay, from the lowest: compounds 2, 3 and 1 (each within the scatter of the next).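

The sulfonyl sulfur now carries three different aryl groups across the series, and in this assay they cannot be told apart, with a number 2 percentage points higher from compound 2 to compound 3 (within the scatter) and a number 1 percentage points lower from compound 1 to compound 3 (within the scatter). Until now only halogen-bearing phenyl groups had been compared at this position; compound 3 shows that 3-methoxyphenyl, with 8 heavy atoms and 1 hydrogen-bond acceptor in place of the 7 heavy atoms and 0 hydrogen-bond acceptors of 4-chlorophenyl, also leaves the number within the scatter. Nothing at hand explains why these exchanges leave the number within the scatter.

Going by these compounds, the read-out comes from a single concentration, so whether compounds 1, 2 and 3 differ in potency remains open. Also open, on these data alone, is whether this position would accept a phenyl group bearing an amine or a carboxylic acid, or a longer alkyl chain in place of the aryl group, with as little effect on the number.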